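A few compounds are considered here, and "the series" means these few. Any claim that something is new, unique, unknown or untested is made for them only; others in the source may bear on it.

Measured so far in a functional assay on A549 cells (Homo sapiens) for inhibition, with a stated time of 48 h, tested at 50 uM; a higher number here means more inhibition of growth at the concentration tested, a lower number less inhibition of growth

- compound 1 `COc1ccc(/C=C/[C@@](C)(/C=C/c2ccc(O)cc2)CCC=C(C)C)cc1` gives 40%
- compound 2 `COc1ccc(/C=C/[C@@](C)(/C=C/c2ccc(O)cc2)CCC=C(C)C)cc1C=O` gives 32%
- compound 3 `CC(C)=CCCC(C)(/C=C/c1ccc(O)cc1)/C=C/c1ccc(O)cc1` gives 33%

Compound 1, at 40%, cannot be ranked against the other two, since both of its measured steps lie within the scatter. Next in line is compound 4 `CC(C)=CCC[C@@](C)(/C=C/c1ccc(N)cc1)/C=C/c1ccc(O)cc1`, still to be measured in this assay. The change from compound 1 is amino in place of methoxy on an aromatic carbon, para to a large group, or 4-methoxyphenyl to 4-aminophenyl (amino in place of methoxy on an aromatic carbon).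

For the measured compounds named here, two measured steps bear on this. The closer guide is a number 7 percentage points lower from compound 1 to compound 3 (within the scatter), which also alters the methoxy group and leaves a hydroxy group in its place. The other is a number 8 percentage points lower from compound 1 to compound 2 (within the scatter), which adds formyl to the aromatic ring that carries the methoxy. Going by the values given here, neither step exceeds the scatter, although no amino compound has been measured, so the guide is indirect. No step beyond the scatter is therefore expected in this assay, and any direction is tentative. The expected change is small, with the estimated step of a number 5 percentage points lower from compound 1 to compound 4 (within the scatter).

For compound 4 the expected value is 35%, with an estimated range from 22% to 48%.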

Compound 4, percent growth inhibition at one concentration: 57%
Compound 4: middle estimate off by 22 percentage points, on the low side; the whole stated range lies below it.
By their numbers in this assay, from the lowest: compounds 2, 3 and 1 (each within the scatter of the next); then compound 4.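

In this assay, for the compounds shown here, the change from 4-methoxyphenyl to 4-aminophenyl gives a number 17 percentage points higher from compound 1 to compound 4 (beyond the scatter), the first step that lies beyond the scatter, so the group on this aromatic carbon, para to a large group, can shift the read-out. The earlier steps shown here on the same ring did not show this: a number 7 percentage points lower from compound 1 to compound 3 (within the scatter) and a number 8 percentage points lower from compound 1 to compound 2 (within the scatter) both stayed within the scatter, and with hydroxy at this place compound 3 gives 33%, whereas with amino compound 4 gives 57%, so losing the methoxy is not enough on its own to give the higher number. Nothing available here explains why amino stands apart from methoxy at this position.

On these data alone, it remains open whether the higher number depends on a free amino group or would persist with a substituted nitrogen group such as methylamino, dimethylamino or acetamido. Also open, as far as these compounds go, is whether amino in place of the hydroxy on the second aromatic ring would move the number further, and whether the result at a single concentration carries over to a full dose-response measurement.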